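Methyl in place of methoxy: compound 2 to compound 4

A few compounds are considered here, and "the series" means these few. Any claim that something is new, unique, unknown or untested is made for them only; others in the source may bear on it.

In an ADME assay, at pH 3 (on this read-out lower numbers stand for a shorter-lived compound and higher numbers for a longer-lived compound), three compounds sharing one core have numbers: compound 1 `COc1cnc(C[S+]([O-])c2nc3cc(OC(F)F)ccc3[nH]2)cc1OC` gives 0.283 h, compound 2 `COc1cnc(C[S+]([O-])c2nc3cc(OC(F)F)ccc3[nH]2)c(C)c1OC` gives 0.2 h and compound 3 `COc1ccnc(C[S+]([O-])c2nc3cc(OC(F)F)ccc3[nH]2)c1` gives 0.117 h. Compound 2 lies within the scatter of both other compounds, so its place among the three shows no clear order. Only compound 1 and compound 3 are separated beyond the scatter.

The next compound is compound 4 `COc1c(C)cnc(C[S+]([O-])c2nc3cc(OC(F)F)ccc3[nH]2)c1C`, and the change from compound 2 is methyl in place of methoxy on an aromatic carbon. This is methyl in place of methoxy on an aromatic carbon, ortho to a methoxy group and para to a large group.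

Going by the values given here, two measured steps bear on it. The closer is a 2.4-fold lower number from compound 1 to compound 3 (0.38 log units; beyond the scatter), where the same methoxy group leaves and hydrogen enters. The other is a 1.4-fold lower number from compound 1 to compound 2 (0.15 log units; within the scatter), which adds a methyl elsewhere on the ring. Among the compounds with values here, no measured step puts methyl in place of methoxy, so the analogy is only partial. A lower number is expected, smaller in size than the closer step. The expected step is a 1.5-fold lower number from compound 2 to compound 4 (0.19 log units; within the scatter). For compound 4 the estimated value is 0.13 h, with an expected range from 0.07 h to 0.23 h.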

Compound 4, half-life: 0.2 h
Estimate against measurement, compound 4: 1.5-fold (0.19 log units) below; measured number inside the range.
By their numbers in this assay, from the lowest: compounds 3, 2, 4 and 1 (each within the scatter of the next, the first and the last beyond it).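

In this assay methyl in place of methoxy at this position gives no change at the digits printed from compound 2 to compound 4 (within the scatter) and so, with the methyl group that both compounds carry on the ring, the methoxy group can be exchanged here without a change that stands out from the scatter. Hydrogen in place of the same methoxy group gave a 2.4-fold lower number from compound 1 to compound 3 (0.38 log units; beyond the scatter) on a background without that methyl group, which suggests that the two replacements need not read alike at this position. The two steps start from different compounds, however, so the contrast cannot be assigned to the entering group alone. Nothing measured here accounts for the flat step.

Still open, going by these compounds, is whether hydrogen at this position, with the methyl group kept, would repeat the step seen on the background without it, which would separate the effect of the entering group from that of the background. Also open, on these data alone, is how an ethyl chain, a chlorine atom or an amine would read here, as methoxy, methyl and hydrogen give only a narrow view of what this position accepts.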